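Notes on a second fluoro in the trifluoromethyl series

The source may report more compounds than this note shows. Statements on the series, on what has been measured and on what is new or still open speak of the compounds shown alone.

Measured so far:
compound 1 `COc1c(F)cccc1C1CCN(c2ccn3c(CC4CC4)nnc3c2Cl)CC1` gives 336%
compound 2 `COc1c(F)ccc(F)c1C1CCN(c2ccn3c(CC4CC4)nnc3c2Cl)CC1` gives 282%
compound 3 `COc1c(F)cccc1C1CCN(c2ccn3c(CC4CC4)nnc3c2C(F)(F)F)CC1` gives 528%

All three numbers come from a functional assay on CHO cells for agonist activity at metabotropic glutamate receptor 2 (Homo sapiens), read by scintillation counting and GTPgammaS binding, with a stated time of 30 min; a higher number here means a larger maximal response, a lower number a smaller maximal response. Compound 3 stands highest of the three, its step to compound 1 and its step to compound 2 both beyond the scatter. Within the data shown here, the change a number 192 percentage points higher from compound 1 to compound 3 (beyond the scatter) is the only measured step leading into compound 3 and it is large.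

Compound 4 `COc1c(F)ccc(F)c1C1CCN(c2ccn3c(CC4CC4)nnc3c2C(F)(F)F)CC1` has not been measured in this assay. It differs from compound 3 as follows: fluoro in place of hydrogen on an aromatic carbon. The same kind of change is already on record once in this series: a number 54 percentage points lower from compound 1 to compound 2 (beyond the scatter). Among the measured compounds shown here, that single step is the one that bears on the move from compound 3 to compound 4; there is no second example to show how steady it is, and the step of a number 192 percentage points higher from compound 1 to compound 3 (beyond the scatter) concerns a different group and does not speak to the fluoro question directly.

Carrying the one measured fluoro step over to compound 3, the expected change is a drop, a number 54 percentage points lower from compound 3 to compound 4 (beyond the scatter), beyond the scatter. The estimate for compound 4 in this assay is therefore 474%, with a likely range from 400% to 560%.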

Compound 4, largest response reached (Emax), in percent of the reference or control that the assay uses: 421%
For compound 4 the middle estimate is 53 percentage points above the measured one, within the range that was stated.
By their numbers in this assay, from the lowest: compound 2; then compound 1; then compound 4; then compound 3.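

In this assay the fluoro ortho to a large group lowers the number on the trifluoromethyl core too, a number 107 percentage points lower from compound 3 to compound 4 (beyond the scatter), so the direction of this change holds on both cores while its size does not: the same change on two cores in this assay, a number 54 percentage points lower (beyond the scatter) from compound 1 to compound 2 and a number 107 percentage points lower (beyond the scatter) from compound 3 to compound 4, 53 percentage points apart, beyond the scatter of two such steps.

Read along the other edge of the same square, trifluoromethyl in place of chloro also raises the number when the 3,6-difluoro-2-methoxyphenyl group is present, a number 139 percentage points higher from compound 2 to compound 4 (beyond the scatter), and this gain differs in size from the one seen with the 3-fluoro-2-methoxyphenyl group: the same change on two cores in this assay, a number 192 percentage points higher (beyond the scatter) from compound 1 to compound 3 and a number 139 percentage points higher (beyond the scatter) from compound 2 to compound 4, 53 percentage points apart, beyond the scatter of two such steps.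

Across these four compounds the fluoro and the trifluoromethyl therefore do not act as separate, additive steps, and a step measured on one core gives the direction on the other but not the size.

Still open, going by these compounds, is whether the drop belongs to fluoro itself or would also follow a methyl or a chloro at this place on the aromatic ring. Also open, on these data alone, is whether a nitrile in place of the trifluoromethyl would make the fluoro step smaller or larger again, since only chloro and trifluoromethyl are compared here.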